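From a Trifluoromethyl Ether to a Chlorophenyl Ether

The source may report more compounds than this note shows. Statements on the series, on what has been measured and on what is new or still open speak of the compounds shown alone.

Of the compounds shown here, three sharing one core have been tested in an ADME assay on Vero cells (Chlorocebus sabaeus) for cytotoxicity, read by MTT assay, with a stated time of 48 h; a higher number here means that more compound is tolerated, a lower number that less compound is tolerated. Compound 1 `CC(C)(C)C(NC(=O)c1ccc([N+](=O)[O-])o1)c1ccccc1` gives 10000 nM, compound 2 `CC(C)(NC(=O)c1ccc([N+](=O)[O-])o1)c1ccc(OC(F)(F)F)cc1` gives 70000 nM, and compound 3 `O=C(NCc1ccc(-c2ccc(Cl)cc2)cc1)c1ccc([N+](=O)[O-])o1` gives 4400 nM. Compound 2 therefore stands highest of the three, with compound 1 nearest and compound 3 furthest; both gaps lie beyond the usual scatter, so compound 2 is the best tolerated of the set.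

Compound 4 `CC(C)(NC(=O)c1ccc([N+](=O)[O-])o1)c1ccc(Oc2ccc(Cl)cc2)cc1` has not yet been measured. It differs from compound 2 in one place: 4-chlorophenyl in place of trifluoromethyl on an oxygen on an aromatic ring. Going by the values given here, no measured pair shows exactly this exchange, so there is no directly comparable step. Among the compounds with values here, the only guide is compound 3, which also carries a 4-chlorophenyl group and gives 4400 nM, the lowest number of the three. On that basis the step is expected to run downward, toward less tolerated, and to reach beyond the scatter: a 3.5-fold lower number from compound 2 to compound 4 (0.54 log units; beyond the scatter) is the estimated size. Compound 4 is expected to give about 20000 nM in this assay, with a likely range from 6000 nM to 60000 nM.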

Compound 4, half-maximal cytotoxic concentration: 67000 nM
Compound 4: middle estimate off by 3.4-fold (0.53 log units), on the low side; the whole stated range lies below it.
By their numbers in this assay, from the lowest: compound 3; then compound 1; then compounds 4 and 2 (each within the scatter of the next).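

On an oxygen on an aromatic ring, 4-chlorophenyl in place of trifluoromethyl gives two numbers that cannot be told apart in this assay: a 1.0-fold lower number from compound 2 to compound 4 (0.02 log units; within the scatter). Going by these compounds alone, this is the first direct look at this exchange, and it shows that on this core a group with a six-membered aromatic ring and 7 heavy atoms can stand where a group of 4 heavy atoms stood with no measurable difference, so carrying 4-chlorophenyl does not by itself bring a low number here. Nothing available explains why the two compounds match.

From the compounds shown here alone, whether a plain methyl, or a phenyl ring bearing a carboxylic acid or an amine, would match on this oxygen remains open. A single pair also cannot show whether the same exchange would read alike on a different core.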